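The source may hold more compounds than are shown below. What is called first, only, known or untested is meant among the compounds shown, and "the series" means these compounds.

In a functional assay on NCI/ADR-RES cells (Homo sapiens) for cytotoxicity, read by sulforhodamine B assay, with a stated time of 48 h, tested at 10 uM (a higher number here means a weaker effect of the compound at the concentration tested, a lower number a stronger effect), compound 1 `COc1ccc(-c2cc(/C=C/C(=O)c3ccc(N)cc3)[nH]n2)cc1` gives 9%. Compound 2 `COc1cc(-c2cc(/C=C/C(=O)c3ccc(Cl)c(Cl)c3)[nH]n2)cc(OC)c1OC` gives 51%, the highest of the two numbers; its nearest neighbour, compound 1, lies lower by a gap beyond the scatter. Compound 3 `COc1ccc(C(=O)/C=C/c2cc(-c3cc(OC)c(OC)c(OC)c3)n[nH]2)cc1` has not yet been measured. It differs from compound 2 in a single place: 4-methoxyphenyl in place of 3,4-dichlorophenyl on a carbonyl carbon. For the measured compounds named here, no step between measured compounds of this kind is available, so the expectation rests on the two values alone. Compound 3 is expected to shift by a number 11 percentage points lower from compound 2 to compound 3 (beyond the scatter), a modest step towards a lower number, close to the scatter. Compound 3 is estimated at 40%, with a range from 15% to 70%.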

Compound 3, a percentage reported as activity, at one concentration (the size of the read-out at that concentration, not a potency): -1%
Beside the measured number, compound 3's estimate is 41 percentage points above it; measured number outside the range, below it.
By their numbers in this assay, from the lowest: compounds 3 and 1 (each within the scatter of the next); then compound 2.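

In this assay, 4-methoxyphenyl in place of 3,4-dichlorophenyl on the carbonyl carbon gives a number 52 percentage points lower from compound 2 to compound 3 (beyond the scatter), towards a stronger effect. With the rest of compound 2 unchanged, this position clearly matters, even though the two groups have the same heavy-atom count. No measurement shown explains the size of this step.

As far as these compounds go, only these two groups can be compared here, so it remains open whether the methoxy group adds to the effect or the loss of the two chlorines accounts for it. A plain phenyl or a 4-hydroxyphenyl on the core of compound 2 would help separate these two readings.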